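Notes on the step from compound 2 to compound 4

The compounds below may be only part of what the source reports. "The series", "measured", "known", "first", "only" and "open" are said of these compounds alone.

- compound 1 `COc1cc(NC(=O)/C=C/c2cccc(OCc3ccccc3)c2)cc(OC)c1OC` gives 21700 nM
- compound 2 `C=C(Br)C(=O)Nc1cccc(/C=C/C(=O)Nc2ccccc2)c1` gives 3900 nM
- compound 3 `C=C(Br)C(=O)Nc1cccc(/C=C/C(=O)Nc2cccc3ccccc23)c1` gives 1160 nM

In a functional assay on LoVo cells (Homo sapiens) for inhibition, read by MTT assay, with a stated time of 72 h (a lower number here means a stronger inhibitor, a higher number a weaker inhibitor), compound 2 stands second highest of the three numbers. Compound 3 lies lower and compound 1 lies higher, and both gaps are beyond the scatter.

The next structure is compound 4 `C=C(Br)C(=O)Nc1cccc(/C=C/C(=O)Nc2ccc(SC(F)(F)F)cc2)c1` which has not yet been measured. It carries (trifluoromethyl)sulfanyl in place of hydrogen on an aromatic carbon, para to a large group ((trifluoromethyl)sulfanyl in place of hydrogen on an aromatic carbon).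

Among the measured compounds shown here, no measured pair differs in one place only, so the expectation rests on little. The closest guide is compound 3 at 1160 nM which shares most of its structure with compound 2. Compound 3 has the lower number of the two, and compound 2 gives 3900 nM here. The expected change is a 2.6-fold lower number from compound 2 to compound 4 (0.41 log units; beyond the scatter) toward a lower number, modestly beyond the scatter. Compound 4 is estimated at 1500 nM with 550 nM to 4200 nM as its expected range.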

Compound 4, half-maximal inhibitory concentration: 29300 nM
Estimate against measurement, compound 4: 20-fold (1.29 log units) below; measured number outside the range, above it.
By their numbers in this assay, from the lowest: compound 3; then compound 2; then compounds 1 and 4 (each within the scatter of the next).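

In this assay the series now has its first step that differs in one place: (trifluoromethyl)sulfanyl in place of hydrogen on an aromatic carbon, para to a large group, gives a 7.5-fold higher number from compound 2 to compound 4 (0.88 log units; beyond the scatter) and so a weaker inhibitor. This aromatic carbon is therefore not a site where any added group is accepted without loss, at least for this substituent on the core of compound 2. Nothing shown gives a measured basis for explaining this loss.

Going by these compounds, it remains open whether the loss belongs to (trifluoromethyl)sulfanyl itself or to any group at this carbon, a question that a fluorine atom, a methoxy group or an amine at the same place could test. A single step also cannot show whether the same change would cost as much on another core.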